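A few compounds are considered here, and "the series" means these few. Any claim that something is new, unique, unknown or untested is made for them only; others in the source may bear on it.

Measured so far in a functional assay on HCT-116 cells (Homo sapiens) for inhibition, read by MTT assay, with a stated time of 2 days; a lower number here means a stronger inhibitor of growth, a higher number a weaker inhibitor of growth:
compound 1 `COc1ccc(OC)c(-c2cn(-c3ccc(O)c(C(=O)Nc4cccc(C(F)(F)F)c4)c3)nn2)c1`, 12900 nM
compound 2 `COc1ccccc1-c1cn(-c2ccc(O)c(C(=O)Nc3cccc(C(F)(F)F)c3)c2)nn1`, 7920 nM
compound 3 `O=C(OCCCc1ccccc1)c1cc(-n2cc(-c3cc(O)ccc3O)nn2)ccc1O`, 20400 nM

Compound 2 gives the lowest of the three numbers in this assay. Its separation from compound 1 is a 1.6-fold lower number from compound 1 to compound 2 (0.21 log units; within the scatter), so the two cannot be told apart on these data. Going by the values given here, compound 3, which carries a different core and a different side chain, shows a number that lies beyond the scatter above that of compound 2; no single-point step joins it to either of the other two.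

Compound 4 `COc1cc(OC)cc(-c2cn(-c3ccc(O)c(C(=O)Nc4cccc(C(F)(F)F)c4)c3)nn2)c1` is not yet measured. Relative to compound 2 the change is 3,5-dimethoxyphenyl in place of 2-methoxyphenyl on an aromatic carbon. Among the compounds with values here, the only measured step that touches the same aryl group is a 1.6-fold lower number from compound 1 to compound 2 (0.21 log units; within the scatter), where loss of one methoxy left the number within the scatter. Compound 4 returns to two methoxy groups, as in compound 1, though in a different arrangement, and compound 1 and compound 2 differ by less than the scatter. The expectation is therefore no step beyond the scatter, with the number for compound 4 estimated at 10000 nM, range 4000 nM to 25000 nM. That estimate corresponds to a step of a 1.3-fold higher number from compound 2 to compound 4 (0.10 log units; within the scatter), which is expected to fall within the scatter.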

Compound 4, concentration for 50% growth inhibition: 4370 nM
Estimate against measurement, compound 4: 2.3-fold (0.36 log units) above; the range from low to high includes it.
By their numbers in this assay, from the lowest: compounds 4, 2, 1 and 3 (each within the scatter of the next, the first and the last beyond it).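

In this assay, going by these compounds alone, the 3,5-dimethoxyphenyl group on the aromatic carbon of the five-membered ring gives the first one-place step that lies beyond the scatter: a 3.0-fold lower number from compound 1 to compound 4 (0.47 log units; beyond the scatter), with 3,5-dimethoxyphenyl in place of 2,5-dimethoxyphenyl. Both groups carry two methoxy substituents, so at this position the arrangement of the methoxy groups can separate two compounds, although the step is modest and rests on this one pair. Against this, a 1.8-fold lower number from compound 2 to compound 4 (0.26 log units; within the scatter), so 3,5-dimethoxyphenyl cannot be told apart from 2-methoxyphenyl, and no evidence bears on the origin of the separation between the two dimethoxyphenyl groups.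

The compounds shown leave open whether an amine or a carboxylic acid on this aryl ring, in place of the methoxy groups, would give a number near that of compound 4. Also open, on these data alone, is whether the step from 2,5-dimethoxyphenyl to 3,5-dimethoxyphenyl recurs when the amide bearing the trifluoromethyl-substituted phenyl ring is replaced by the phenylpropyl ester side chain of compound 3.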